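Series notes: 2-methylphenyl to 3-methylphenyl on the amine nitrogen

The source may hold more compounds than are shown below. What is called first, only, known or untested is meant among the compounds shown, and "the series" means these compounds.

Measured compounds in a functional assay on Bel-7402 cells (Homo sapiens) for cytotoxicity, read by MTT assay; on this read-out higher numbers stand for weaker inhibition and lower numbers for stronger inhibition:
- compound 1 `Cc1ccccc1Nc1nc(C)c(C(=O)/C=C/c2ccc(Cl)cc2)s1` gives > 25000 nM, which is a limit of the assay.
- compound 2 `COc1cc(/C=C/C(=O)c2sc(Nc3ccccc3C)nc2C)cc(OC)c1OC` gives 10300 nM.
- compound 3 `Cc1cccc(Nc2nc(C)c(C(=O)/C=C/c3ccc(Cl)cc3)s2)c1` gives > 25000 nM, which is a limit of the assay.

Going by the values given here, compound 2 holds the only number among the three; the other two values are limits. The difference between the core of compound 1 and the core of compound 2 is not broken down here.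

From compound 1 to compound 3 the change is 3-methylphenyl in place of 2-methylphenyl on a nitrogen on an aromatic ring. The step it made, a step that the two limits leave unreadable from compound 1 to compound 3, cannot be read, because both compounds sit at the limit of > 25000 nM in this assay, at which 2 of the 3 values shown sit.

Compound 4 `COc1cc(/C=C/C(=O)c2sc(Nc3cccc(C)c3)nc2C)cc(OC)c1OC` is not yet measured in this assay. It differs from compound 2 by 3-methylphenyl in place of 2-methylphenyl on a nitrogen on an aromatic ring, the same change as from compound 1 to compound 3, at the same place. Among the compounds with values here, the one earlier instance of this change gives no readable size, so the expectation for compound 4 rests mainly on the value of compound 2, 10300 nM, with the change taken as roughly neutral. Compound 4 is therefore estimated at 13000 nM in this assay, with a range from 5000 nM to 30000 nM. The expected step from compound 2 to compound 4 is a 1.3-fold higher number from compound 2 to compound 4 (0.10 log units; within the scatter). Because compound 1 and compound 3 both sit at the limit of > 25000 nM in this assay, at which 2 of the 3 values shown sit, a limit rather than a number is also a real possibility for compound 4.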

Compound 4, half-maximal inhibitory concentration: > 25000 nM
Compound 4: no number, only a limit (the forecaster's own chance of this, stated with the estimate: 30%); middle value at least 1.9-fold (0.28 log units) from the limit.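

In this assay, going by these compounds alone, 3-methylphenyl in place of 2-methylphenyl on a nitrogen on an aromatic ring gives an at least 2.4-fold higher number from compound 2 to compound 4 (0.38 log units; beyond the scatter), so the one readable instance of this change points toward weaker inhibition. Within the data shown here, that size is only a lower bound and the full size of the step stays unknown, because compound 4 gives a limit and not a number: the limit of > 25000 nM in this assay, at which 3 of the 4 values shown sit. The same change from compound 1 to compound 3 cannot be read, with limits at both ends, so the two cores offer no pair of sizes to compare, and the series neither confirms nor rules out that the change carries over from one core to the other with a similar effect.

The compounds shown leave open how the amine nitrogen tolerates anything other than these two methylphenyl groups, such as a plain phenyl, a methoxyphenyl or a morpholine in their place. With only compound 2 holding a number, they also leave open which parts of the shared core matter in this assay, and a carboxylic acid or a basic amine on the aromatic ring on that nitrogen would be a separate question.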